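Swapping the Halophenyl Ring in a Methylsulfonyl Chromone Series

The source may hold more compounds than are shown below. What is called first, only, known or untested is meant among the compounds shown, and "the series" means these compounds.

Measured compounds:
Compound 1, `NS(=O)(=O)c1ccc(-c2oc3ccccc3c(=O)c2-c2ccc(F)cc2)cc1`: 67%
Compound 2, `CS(=O)(=O)c1ccc(-c2oc3ccccc3c(=O)c2-c2ccc(Cl)cc2)cc1`: < 5%
Compound 3, `CSc1ccc(-c2c(-c3ccc(S(N)(=O)=O)cc3)oc3ccccc3c2=O)cc1`: 90%

Going by the values given here, in an assay on isolated protein for inhibition of prostaglandin G/H synthase 1 (Mus musculus), tested at 10 ug/mL (a higher number here means more inhibition at the concentration tested (going by the name of the read-out), a lower number less inhibition), compound 2 gives only a limit of the assay, < 5%, as the limit of < 5% in this assay, at which 1 of the 3 values shown sits, records; it stands below compound 1 and compound 3, and no numerical step can be drawn from it. Compound 4, `CS(=O)(=O)c1ccc(-c2oc3ccccc3c(=O)c2-c2cccc(F)c2)cc1`, differs from compound 2 as follows: 3-fluorophenyl in place of 4-chlorophenyl on an aromatic carbon.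

Among the compounds with values here, the one measured step, a number 23 percentage points higher from compound 1 to compound 3 (beyond the scatter), changes a different ring of the core and so does not bear directly on this change. Within the data shown here, no measured pair shows a halophenyl swap. Compound 4 is therefore estimated near the low end, with a number at least 5 percentage points higher from compound 2 to compound 4 (that floor lies within the scatter) as the expected step. The estimate for compound 4 is 10%, ranging from 0% to 35%.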

Compound 4, a percentage reported as inhibition, at one concentration (the size of the read-out at that concentration, not a potency): < 5%
Compound 4 gave a limit, no number (the forecaster's own chance of this, stated with the estimate: 50%); at least 5 percentage points between middle value and limit.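

Going by these compounds alone, compound 2 and compound 4 both stand at a limit in this assay, so no step between them can be read: the limit of < 5% in this assay, at which 2 of the 4 values shown sit. The compounds shown leave open whether 3-fluorophenyl and 4-chlorophenyl differ at all in this assay.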